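This account rests on a few compounds, and the source may have more. Where it says the series, first, only, none or still open, it means among the compounds named here.

Series so far, in a functional assay on ECa-109 cells (Homo sapiens) for cytotoxicity, read by MTT assay, with a stated time of 72 h; a lower number here means a stronger inhibitor, a higher number a weaker inhibitor

- Compound 1 `COc1ccc(C=C2C(=O)N(c3ccc(Cl)cc3)N(c3ccc(Cl)cc3)C2=O)cc1` gives > 128000 nM (a limit of the assay)
- Compound 2 `O=C1C(=Cc2ccco2)C(=O)N(c2ccc(Cl)cc2)N1c1ccc(Cl)cc1` gives 14300 nM (a number)
- Compound 3 `O=C1C(=Cc2ccccc2)C(=O)N(c2ccc(Cl)cc2)N1c1ccc(Cl)cc1` is not yet measured

For the measured compounds named here, compound 2 carries the only actual number, since the value for compound 1 is a limit. Compound 3 changes compound 2 in one place, with phenyl in place of furan-2-yl on a double-bonded chain carbon bound to a double-bonded ring carbon. Going by the values given here, one measured step bears on this, at the same place: an at least 8.9-fold lower number from compound 1 to compound 2 (0.95 log units; beyond the scatter) on going to furan-2-yl from 4-methoxyphenyl. Leaving furan-2-yl for a six-membered aromatic ring of carbon only therefore points to a partial return towards the weaker side, though this rests on a single step. The expected change is a 3.1-fold higher number from compound 2 to compound 3 (0.50 log units; beyond the scatter), towards a higher number. Compound 3 is estimated at 45000 nM, with an expected range from 14000 nM to 128000 nM.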

Compound 3, half-maximal inhibitory concentration: 32700 nM
Estimate against measurement, compound 3: 1.4-fold (0.14 log units) above; measured number inside the range.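

In this assay, the furan-2-yl group now has a direct comparison with an unsubstituted ring at this place on the double-bonded chain carbon: a 2.3-fold higher number from compound 2 to compound 3 (0.36 log units; beyond the scatter). The advantage of furan-2-yl over phenyl is beyond the scatter but modest, so part of the earlier gain remains when phenyl is present. The second new comparison isolates the methoxy group on the aromatic carbon, an at least 3.9-fold lower number from compound 1 to compound 3 (0.59 log units; beyond the scatter), but this gives only a minimum size for the step, as compound 1 has a limit and not a number: the limit of > 128000 nM in this assay, at which 1 of the 3 values shown sits.

As far as these compounds go, it remains open how a thiophene or pyridine ring would compare with furan-2-yl at this place. Also open, from the compounds shown here alone, is how an amine or a carboxylic acid on the phenyl ring would compare with the hydrogen of compound 3.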